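Ethyl-to-Propyl and Ethyl-to-Isopropyl Chain Growth on Two Cores

A few compounds are considered here, and "the series" means these few. Any claim that something is new, unique, unknown or untested is made for them only; others in the source may bear on it.

The measured compounds and their values:
compound 1, `CCOC(=O)C1=C(C)N(C)C(=O)NC1c1ccsc1`: 53%
compound 2, `CCCOC(=O)C1=C(C)N(C)C(=O)NC1c1ccsc1`: 1%
compound 3, `CCNC(=O)C1=C(C)NC(=O)NC1c1ccco1`: 1%

In an assay on membranes from HEK293 cells for displacement of a labelled ligand from adenosine receptor A2b (Homo sapiens), read by scintillation counting, with a stated time of 30 min, tested at 1 uM (a higher number here means more inhibition at the concentration tested (going by the name of the read-out), a lower number less inhibition), compound 1 gives 53%. Compound 2 carries methyl in place of hydrogen on a saturated chain carbon, two bonds along the chain from an oxygen next to a carbonyl group and in this assay compound 2 gives 1%; the step is a number 52 percentage points lower from compound 1 to compound 2 (beyond the scatter). Compound 3 sits on a different core, and the difference between the two cores is not broken down here; in this assay compound 3 gives 1%, level with compound 2 at the digits shown.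

Compound 4, `CC1=C(C(=O)NC(C)C)C(c2ccco2)NC(=O)N1`, has not yet been measured. It differs from compound 3 by methyl in place of hydrogen on a saturated chain carbon bound to an amide-type nitrogen and a saturated chain carbon. This is the same kind of change as from compound 1 to compound 2, but not the same: there the methyl entered on a saturated chain carbon two bonds along the chain from an oxygen next to a carbonyl group, here on a saturated chain carbon bound to an amide-type nitrogen and a saturated chain carbon. Going by the values given here, the one measured example of this change, a number 52 percentage points lower from compound 1 to compound 2 (beyond the scatter), is large, yet compound 3 already stands at the bottom of the three values with 1%, so there is little room for a further fall. The step is therefore expected to be small, a number 2 percentage points higher from compound 3 to compound 4 (within the scatter). Compound 4 is expected to give about 3% in this assay, within 0% to 15%.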

Compound 4, a percentage reported as inhibition, at one concentration (the size of the read-out at that concentration, not a potency): 2%
Beside the measured number, compound 4's estimate is 1 percentage points above it, within the range that was stated.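

In this assay the added methyl does not act alike in the two pairs, and the new step, a number 1 percentage points higher from compound 3 to compound 4 (within the scatter), stands well apart from the earlier one: the same change on two cores in this assay, a number 52 percentage points lower (beyond the scatter) from compound 1 to compound 2 and a number 1 percentage points higher (within the scatter) from compound 3 to compound 4, 53 percentage points apart, beyond the scatter of two such steps. The large fall seen with the core of compound 1 therefore cannot be carried over as a rule to the core of compound 3. This does not show that the core alone sets the gap: the methyl enters at a different place in the two pairs, and compound 3 gives only 1%, which leaves almost no room for a fall to appear.

The compounds shown leave open whether an added methyl would lower the number on the core of compound 3 if a member of that core started from a clearly higher value. Also open, on these data alone, is what a longer chain, such as butyl, or a chain ending in an amine would do on either core.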